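The source may report more compounds than this note shows. Statements on the series, on what has been measured and on what is new or still open speak of the compounds shown alone.

Of the compounds shown here, three have been measured in an assay on membranes from brain for binding affinity to Monoglyceride lipase (Mus musculus), read by fluorescence, with stated times of 1 h and 30 min; on this read-out higher numbers stand for weaker inhibition and lower numbers for stronger inhibition. Compound 1 `Cc1cnn(C(=O)NCc2ccc(OCc3ccccc3)cc2)c1` gives 1000 nM, compound 2 `Cc1cnn(C(=O)N2CCCCC2)c1` gives 9200 nM, and compound 3 `Cc1cnn(C(=O)N2CCCN(Cc3ccc(OCc4ccccc4)cc3)CC2)c1` gives 9500 nM. Compound 3 holds the highest number of the three; against compound 2 the gap is within the scatter, while against compound 1 it is beyond the scatter. Compound 4 `N#Cc1cnn(C(=O)N2CCCN(Cc3ccc(OCc4ccccc4)cc3)CC2)c1` differs from compound 3 in one place: cyano in place of methyl on an aromatic carbon. Among the compounds with values here, no measured pair shows this change, so the expectation rests on compound 3 alone. A modest shift in either direction is expected, possibly none beyond the scatter, which a 1.9-fold lower number from compound 3 to compound 4 (0.28 log units; within the scatter) reflects. Compound 4 is therefore estimated at 5000 nM, within 1200 nM to 20000 nM.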

Compound 4, half-maximal inhibitory concentration: 10000 nM
Estimate against measurement, compound 4: 2.0-fold (0.30 log units) below; measured number inside the range.
By their numbers in this assay, from the lowest: compound 1; then compounds 2, 3 and 4 (each within the scatter of the next).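

In this assay, replacing 4-methyl-1H-pyrazol-1-yl with 4-cyano-1H-pyrazol-1-yl gives a 1.1-fold higher number from compound 3 to compound 4 (0.02 log units; within the scatter), so the two compounds cannot be told apart. Within the data shown here, this is the first direct test of this position, and on this scaffold the assay does not distinguish cyano from methyl there, even though cyano adds a hydrogen-bond acceptor. No supporting data explain this result. Still open, from the compounds shown here alone, is how an amine or a carboxylic acid at this position would read, and whether the same swap would matter on the core of compound 1.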